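The source may hold more compounds than are shown below. What is called first, only, known or untested is meant among the compounds shown, and "the series" means these compounds.

Measured compounds and their readings:

- compound 1, `COc1ccccc1N1C(=O)CSC1c1cc(F)cc(C(=O)O)c1`: 0%
- compound 2, `CCN1C(=O)CSC1c1cccc(C(=O)NCCCCc2ccccc2)c1`: 0%
- compound 3, `COc1ccccc1N1C(=O)CSC1C(=O)NCCCCc1ccccc1`: 60%

In a functional assay on MG-63 cells (Homo sapiens) for inhibition, read by CCK-8 assay, with a stated time of 72 h, tested at 1 uM (a higher number here means more inhibition at the concentration tested (going by the name of the read-out), a lower number less inhibition), compound 1 gives 0% and compound 2 gives 0%. These two readings are level at the digits shown and together form the floor of the set. Compound 3 stands apart from both: in this assay compound 3 gives 60%, a gap to compound 2 that lies well beyond the scatter. Within the data shown here, compound 3 and compound 2 differ in more than one place, so no single step can be named for that gap.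

The unmeasured compound 4, `COc1ccc(N2C(=O)CSC2c2cccc(C(=O)NCCCCc3ccccc3)c2)c(OC)c1`, is reached from compound 2 by one change: 2,4-dimethoxyphenyl in place of ethyl on an amide-type nitrogen in a ring. A methoxy-bearing aryl on the ring nitrogen is present in compound 3, which shows the high reading, but also in compound 1, which shows the floor reading, so the aryl alone does not settle the outcome. A rise is expected for compound 4, but a guarded one. For compound 4 the step of a number 15 percentage points higher from compound 2 to compound 4 (beyond the scatter) is expected to be modest and upward. Compound 4 is estimated at 15%, with a range from 0% to 45%.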

Compound 4, a percentage reported as inhibition, at one concentration (the size of the read-out at that concentration, not a potency): 56%
The estimate for compound 4 lay 41 percentage points below the measured number; the measured number lies above the stated range.
By their numbers in this assay, from the lowest: compounds 1 and 2 (each within the scatter of the next); then compounds 4 and 3 (each within the scatter of the next).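

On the amide-type nitrogen in a ring, 2,4-dimethoxyphenyl in place of ethyl is enough on its own to lift the reading off the floor: this assay shows a number 56 percentage points higher from compound 2 to compound 4 (beyond the scatter) with the rest of compound 2 held fixed. The earlier compounds shown here differed in more than one place, so they could not tie any change in the reading to this position; the substituent on this nitrogen now stands as a single change that moves the reading. Nothing at hand gives a reason for the size of this step.

Still open, going by these compounds, is which feature of the 2,4-dimethoxyphenyl carries the step, since an unsubstituted phenyl or a pyridine ring on this nitrogen would separate the aromatic ring from its methoxy groups, and a longer alkyl chain such as hexyl would test whether an aromatic ring is needed there at all. Also open, on these data alone, is how far the step depends on the rest of the molecule, as compound 1 carries a methoxy-bearing aryl on this nitrogen yet gives 0% in this assay with a different group elsewhere on the core.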